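Chain terminus of a leukotriene receptor series

A few compounds are considered here, and "the series" means these few. Any claim that something is new, unique, unknown or untested is made for them only; others in the source may bear on it.

Compound 1 `CCc1cc(C(C)=O)c(O)cc1OCCCCC#N` gives 92% in an assay on isolated protein for inhibition of leukotriene B4 receptor 1 (Homo sapiens), tested at 10 uM; on this read-out lower numbers stand for less inhibition and higher numbers for more inhibition at the one concentration tested (going by the name of the read-out). Compound 2 `CCCCCCc1cc(C(C)=O)c(O)cc1OCCCCC#N` gives 51%. Compound 3 `CC(=O)c1cc(C=O)c(OCCCCC#N)cc1O` gives 6%.

Compound 1 stands highest of the three; the nearest is compound 2, with the step of a number 41 percentage points lower from compound 1 to compound 2 (beyond the scatter), and the furthest is compound 3, with a number 86 percentage points lower from compound 1 to compound 3 (beyond the scatter). Compound 4 `CCc1cc(C(C)=O)c(O)cc1OCCCCCC(C)(C)C(=O)O` differs from compound 1 by 2-carboxy-2-methylpropyl in place of cyano on a saturated chain carbon, four bonds along the chain from an oxygen on an aromatic ring. For the measured compounds named here, both measured steps change the core substituents and leave the chain end untouched, so neither bears directly on this change; the data give no step at the chain end. The expected step is therefore uncertain and taken as a modest loss, a number 20 percentage points lower from compound 1 to compound 4 (beyond the scatter). Compound 4 is estimated at 72%, within 40% to 95%.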

Compound 4, a percentage reported as inhibition, at one concentration (the size of the read-out at that concentration, not a potency): 104%
Compound 4: middle estimate off by 32 percentage points, on the low side; the whole stated range lies below it.
By their numbers in this assay, from the lowest: compound 3; then compound 2; then compound 1; then compound 4.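

For the compounds shown here, this is the first step at the chain end, on a saturated chain carbon, four bonds along the chain from an oxygen on an aromatic ring. Unlike the earlier steps, which all lead downward, 2-carboxy-2-methylpropyl in place of cyano gives a number 12 percentage points higher from compound 1 to compound 4 (beyond the scatter) in this assay, so the nitrile is not needed to hold this read-out. Nothing measured here accounts for the rise. Going by these compounds, it remains open whether the carboxylic acid or the branching matters more. An unbranched carboxylic acid, a primary amide or a tetrazole at this chain end would separate them.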